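The source may hold more compounds than are shown below. What is called first, only, known or untested is meant among the compounds shown, and "the series" means these compounds.

Three compounds built on one shared core were tested in an ADME assay on ECV-304 cells (Homo sapiens) for cytotoxicity, read by MTT assay, with a stated time of 72 h; a lower number here means a stronger inhibitor, a higher number a weaker inhibitor. Compound 3 `COc1ccc(C2=C(c3cc(OC)c(OC)c(OC)c3)C(=O)CC2O)cc1` reaches only the limit of the measurement, > 100 ug/mL. Compound 1 `COc1ccc(C2=C(c3cc(OC)c(OC)c(OC)c3)C(=O)CC2O[SiH2]C(C)(C)C)cc1` differs from it by a group of 5 heavy atoms (4 carbon, 1 silicon; no ring) in place of a hydrogen atom, on an oxygen on a saturated carbon. In this assay compound 1 likewise reaches only the limit, > 100 ug/mL. The step from compound 3 to compound 1 is therefore a step that the two limits leave unreadable from compound 3 to compound 1; both values sit at the limit of > 100 ug/mL in this assay, at which 3 of the 3 values shown sit, so no size can be read from the pair. Compound 2 `COc1ccc(C2=C(c3cc(OC)c(OC)c(OC)c3)CC(O)C2=O)cc1[N+](=O)[O-]` carries a core whose difference from the core of compound 3 is not broken down here. In this assay compound 2 also reaches only the limit, > 100 ug/mL.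

Compound 4 `COc1ccc(C2=C(c3cc(OC)c(OC)c(OC)c3)CC(O[SiH2]C(C)(C)C)C2=O)cc1[N+](=O)[O-]` has not yet been measured. It differs from compound 2 by a group of 5 heavy atoms (4 carbon, 1 silicon; no ring) in place of a hydrogen atom, on an oxygen on a saturated carbon, the same change that turns compound 3 into compound 1, at the same place. Going by the values given here, because every value so far sits at the limit of > 100 ug/mL in this assay, at which 3 of the 3 values shown sit, the step from compound 2 to compound 4 is expected to be a step that the limit leaves unreadable from compound 2 to compound 4. Compound 4 is estimated to give about 150 ug/mL, between 60 ug/mL and 400 ug/mL, and most likely to be reported only as a limit.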

Compound 4, half-maximal inhibitory concentration: > 100 ug/mL
Compound 4: only a limit was reported; the forecaster's own chance of this, stated with the estimate: 85%; the middle value lies beyond the limit too.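

Compound 4, like compound 2, gives only a limit, so no size can be read for the step between them, and the same holds for compound 3 and compound 1: the limit of > 100 ug/mL in this assay, at which 4 of the 4 values shown sit. What the compounds shown leave open is whether this silicon-bearing group, in place of the hydrogen atom, changes the result in this assay at all, and how the four compounds would rank there.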